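From a Methyl to a Bromine on the Shared Core

This account rests on a few compounds, and the source may have more. Where it says the series, first, only, none or still open, it means among the compounds named here.

Compound 1 `COc1ccc(/C=C/c2cc(OC)cc(OC)c2/C=C/C(=O)c2cc3cccc(C)c3oc2=O)cc1` was tested in an assay on isolated protein for inhibition of Amine oxidase [flavin-containing] A (Homo sapiens), read by fluorescence, with a stated time of 15 min; on this read-out higher numbers stand for weaker inhibition and lower numbers for stronger inhibition. In this assay compound 1 returns only a limit, > 60000 nM. Compound 2 `COc1ccc(/C=C/c2cc(OC)cc(OC)c2/C=C/C(=O)c2cc3ccc(OC)cc3oc2=O)cc1` likewise returns only a limit, > 60000 nM. Compound 1 therefore stands at the limit of > 60000 nM in this assay, at which 2 of the 3 values shown sit, with no number of its own among the values shown. Within the data shown here, compound 3 `CCOc1cccc2cc(C(=O)/C=C/c3c(/C=C/c4ccc(OC)cc4)cc(OC)cc3OC)c(=O)oc12` gives 3200 nM in this assay, and the step of an at least 18-fold lower number from compound 1 to compound 3 (1.27 log units; beyond the scatter) is the only measured change that starts from compound 1.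

Compound 4 `COc1ccc(/C=C/c2cc(OC)cc(OC)c2/C=C/C(=O)c2cc3cc(Br)ccc3oc2=O)cc1` has not yet been measured in this assay. It differs from compound 1 by a group of 12 heavy atoms (9 carbon, 2 oxygen, 1 bromine; one six-membered aromatic ring of carbon only, one six-membered aromatic ring with 1 hetero atom) in place of a group of 12 heavy atoms (10 carbon, 2 oxygen; one six-membered aromatic ring of carbon only, one six-membered aromatic ring with 1 hetero atom), on a carbonyl carbon. Among the measured compounds shown here, the one measured step, from compound 1 to compound 3, replaces the methyl with an ethoxy rather than with a bromine-bearing group, so it bears only loosely on this change. With two of the three measured values sitting at the limit, compound 4 is expected to give a weak number, likely near that limit, and the expected step is an at least 1.5-fold lower number from compound 1 to compound 4 (0.17 log units; that floor lies within the scatter). The estimate for compound 4 is 40000 nM, in a range from 10000 nM to 150000 nM.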

Compound 4, half-maximal inhibitory concentration: 12100 nM
Compound 4: the middle estimate sits 3.3-fold (0.52 log units) above what was measured, and the stated range covers the measured number.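

In this assay the bromine-bearing group on the carbonyl carbon gives an at least 4.9-fold lower number from compound 1 to compound 4 (0.69 log units; beyond the scatter), so the ethoxy of compound 3 is no longer the only replacement at this place that yields a measured number. An oxygen-linked group is therefore not needed for a number to appear, since the group that enters in compound 4 carries bromine in place of the methyl and has no added oxygen. Even so, the limit remains common among the compounds shown: the limit of > 60000 nM in this assay, at which 2 of the 4 values shown sit.

The compounds shown leave open whether a chlorine or an amine in place of the bromine would also give a measured number. Among these compounds, they also leave open whether a longer chain than ethoxy would move the number further, and no step links compound 3 with compound 4 directly.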